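A few compounds are considered here, and "the series" means these few. Any claim that something is new, unique, unknown or untested is made for them only; others in the source may bear on it.

Measured so far in a physicochemical assay for permeability, using PAMPA; a lower number here means that the compound crosses the layer more slowly, a higher number that the compound crosses the layer faster:

Compound 1, `Cc1oc(-c2c(C)c(C)c(C)c(C)c2C)nc1CN1CCC(C(=O)NCCCN2C[C@H](C)C[C@H](C)C2)CC1`, gives 455 10^-6 cm/s.
Compound 2, `Cc1ccccc1-c1nc(CN2CCC(C(=O)NCCCCN3C[C@H](C)C[C@H](C)C3)CC2)c(C)o1`, gives 288 10^-6 cm/s.
Compound 3, `Cc1cccc(Cl)c1-c1nc(CN2CCC(C(=O)NCCCN3CCCC(C)C3)CC2)c(C)o1`, gives 651 10^-6 cm/s.

Compound 1 holds the second highest of the three numbers in this assay. Its nearest neighbour is compound 3, and the gap between them lies within the scatter; the widest gap is to compound 2, and that gap too lies within the scatter. No two of the three values can therefore be placed in any order, and the three compounds are taken as indistinguishable in this assay on the numbers shown.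

Compound 4, `Cc1cccc(F)c1-c1nc(CN2CCC(C(=O)NCCCN3C[C@H](C)C[C@H](C)C3)CC2)c(C)o1`, has not yet been measured. Relative to compound 1 the change is 2-fluoro-6-methylphenyl in place of 2,3,4,5,6-pentamethylphenyl on an aromatic carbon. No step between two measured compounds isolates this change, so what the change does to this assay is not known from the shown data. Given that compound 1, compound 2 and compound 3 sit within the scatter of one another despite differing in the same region, no step beyond the scatter is expected from compound 1 to compound 4. Compound 4 is estimated at 450 10^-6 cm/s, with a range from 250 10^-6 cm/s to 800 10^-6 cm/s, which means an expected step of a 1.0-fold lower number from compound 1 to compound 4 (0.00 log units; within the scatter).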

Compound 4, apparent permeability: 234 10^-6 cm/s
Beside the measured number, compound 4's estimate is 1.9-fold (0.28 log units) above it; the whole stated range lies above it.
By their numbers in this assay, from the lowest: compounds 4, 2, 1 and 3 (each within the scatter of the next, the first and the last beyond it).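

In this assay, among the compounds shown here, the step for 2-fluoro-6-methylphenyl in place of 2,3,4,5,6-pentamethylphenyl is a 1.9-fold lower number from compound 1 to compound 4 (0.29 log units; within the scatter), the first step that isolates a change at this aromatic carbon. Going from 11 heavy atoms to 8, and from carbon alone to a group with one fluorine, therefore produces no readable difference in this read-out at this position. Nothing available bears on a cause for this result.

For the compounds shown here, compound 2 and compound 3 each differ from compound 1 in more than one place, so the chain on the amide nitrogen and the amine at its end still have no single-place step of their own. As far as these compounds go, it also remains open how a pyridine ring or a phenyl ring carrying a carboxylic acid at this position would read in this assay.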